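Cyclopentyl for oxetanyl on the sulfonyl of compound 1

This account rests on a few compounds, and the source may have more. Where it says the series, first, only, none or still open, it means among the compounds named here.

Three compounds sharing a spiro-amine amide core have been run in an ADME assay on microsomes from liver (Homo sapiens) for metabolic stability, read by LC-MS, with a stated time of 40 min, tested at 0.5 uM; on this read-out higher numbers stand for fast clearance and lower numbers for slow clearance. Compound 1 `O=C(Nc1cccc(S(=O)(=O)C2COC2)c1)c1cccnc1N1CCC2(CC1)CC2` gives 183 mL.min-1.g-1. Compound 2 `CC(C)(C)NS(=O)(=O)c1cccc(NC(=O)c2ccc(NC3(CO)CC3)cc2N2CCC3(CC2)CC3)n1` gives 83 mL.min-1.g-1, and compound 3 `CC(C)(C)NS(=O)(=O)c1cccc(NC(=O)c2ccc(NC(C)(C)CO)cc2N2CCC3(CC2)CC3)n1` gives 189 mL.min-1.g-1. Among these three numbers compound 1 stands second highest; its nearest neighbour is compound 3, within the usual scatter, while compound 2 sits further off, beyond it. Among the compounds with values here, the one single-point step so far, a 2.3-fold higher number from compound 2 to compound 3 (0.36 log units; beyond the scatter), concerns the substituent on the aromatic nitrogen, a part of the molecule that is untouched in the change considered here.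

Compound 4 `O=C(Nc1cccc(S(=O)(=O)C2CCCC2)c1)c1cccnc1N1CCC2(CC1)CC2` differs from compound 1 in one place: cyclopentyl in place of oxetan-3-yl on a sulfonyl sulfur. Within the data shown here, no measured step touches the sulfonyl substituent, so nothing in this assay directly anchors the outcome. With compound 1 already near the top of the three numbers, the writer expects compound 4 to land near it, with a modest lean upward, a 1.4-fold higher number from compound 1 to compound 4 (0.14 log units; within the scatter), rather than anything beyond a small step. The estimate for compound 4 in this assay is therefore 250 mL.min-1.g-1, with a range from 130 mL.min-1.g-1 to 480 mL.min-1.g-1.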

Compound 4, intrinsic clearance in microsomes: > 399 mL.min-1.g-1
Compound 4 ended at the assay's limit; the forecaster's own chance of this, stated with the estimate: 5%; middle value at least 1.5-fold (0.20 log units) from the limit.
By their numbers in this assay, from the lowest: compound 2; then compounds 1 and 3 (each within the scatter of the next). At a limit, above all of these: compound 4.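

Within the data shown here, until now no step in this assay touched the sulfonyl substituent; cyclopentyl in place of oxetan-3-yl on a sulfonyl sulfur gives an at least 2.1-fold higher number from compound 1 to compound 4 (0.33 log units; beyond the scatter), which shows that the read-out responds to a change at this position. Compound 4 stands at a limit of this assay and not at a number, so the step gives only a floor and its full size stays unread: the limit of > 399 mL.min-1.g-1 in this assay, at which 1 of the 4 values shown sits. Oxetan-3-yl has a four-membered ring with a hetero atom and cyclopentyl a five-membered ring of carbon only, and this single step cannot say which of those differences goes with the rise.

As far as these compounds go, it remains open whether cyclobutyl, a smaller ring of carbon only, or tetrahydrofuran-3-yl, an oxygen ring of the same size as cyclopentyl, would fall with compound 1 or with compound 4. Also open, from the compounds shown here alone, is whether a hydroxyl or an amine on the cyclopentyl ring would bring the number back inside the measurable range of this assay.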